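Title: From an Ester to a Primary Amide in the Series

A few compounds are considered here, and "the series" means these few. Any claim that something is new, unique, unknown or untested is made for them only; others in the source may bear on it.

Compound 3 `COC(C)(C)CCCC(C)C/C=C/C(C)=C/C(=O)OC1CCCC1` gives 7.01 in a physicochemical assay for lipophilicity (on this read-out higher numbers stand for higher lipophilicity and lower numbers for lower lipophilicity), the second highest of the three numbers measured. Compound 1 `COC(C)(C)CCCC(C)C/C=C/C(C)=C/C(=O)OCCC(C)C` gives 7.03, and a number 0.02 log units lower from compound 1 to compound 3 (within the scatter). Compound 2 `C=CCOC(=O)/C=C(C)/C=C/CC(C)CCCC(C)(C)OC` gives 5.53, so a number 1.48 log units higher from compound 2 to compound 3 (beyond the scatter) and a number 1.50 log units lower from compound 1 to compound 2 (beyond the scatter). Compound 4 `COC(C)(C)CCCC(C)C/C=C/C(C)=C/C(N)=O` has not yet been measured. It differs from compound 3 in one place: amino in place of cyclopentyloxy on a carbonyl carbon. The step from compound 2 to compound 3 and the step from compound 1 to compound 2 bear on this change, since both alter what sits on the oxygen next to the carbonyl group and both were large, while the swap of cyclopentyl for isopentyl was within the scatter. The change to compound 4 removes the whole cyclopentyloxy group and brings in amino, which exceeds those steps in what is counted. Compound 4 is therefore expected to fall well beyond the scatter, with a step of a number 3.71 log units lower from compound 3 to compound 4 (beyond the scatter). The estimate for compound 4 is 3.3, with a range from 2.5 to 4.1.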

Compound 4, partition coefficient: 3.52
Compound 4: middle estimate off by 0.22 log units, on the low side; low and high end bracket the measured number.
By their numbers in this assay, from the lowest: compound 4; then compound 2; then compounds 3 and 1 (each within the scatter of the next).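

Of the compounds shown, only compound 4 changes the atom on the carbonyl carbon itself, and amino in place of the alkoxy groups takes the number in this assay well down from every ester (a number 3.49 log units lower from compound 3 to compound 4 (beyond the scatter); a number 3.51 log units lower from compound 1 to compound 4 (beyond the scatter); a number 2.01 log units lower from compound 2 to compound 4 (beyond the scatter)). The earlier compounds shown here varied only what sits on the oxygen, so they could not show that the lowest of the esters, compound 2, still stands clearly above the primary amide. Nothing in the data explains the size of these drops.

From the compounds shown here alone, it remains open whether a methylamino or dimethylamino group on the carbonyl carbon would stay close to amino or move back towards the esters. Going by these compounds, a carboxylic acid in the same place is equally open, as is whether the change would run the same way on a different core.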